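The source may report more compounds than this note shows. Statements on the series, on what has been measured and on what is new or still open speak of the compounds shown alone.

Working notes on the series. Of the compounds shown here, three have numbers so far in an assay for inhibition of Polyunsaturated fatty acid 5-lipoxygenase (Homo sapiens); on this read-out lower numbers stand for stronger inhibition and higher numbers for weaker inhibition. Compound 1 `CCOC(=O)CSc1nc(Cl)cc(Nc2ccc3ncccc3c2)n1` gives 2600 nM, compound 2 `CCCCCCC(Sc1nc(Cl)cc(Oc2ccc3ncccc3c2)n1)C(=O)OCC` gives 1700 nM, and compound 3 `O=C(O)CSc1nc(Cl)cc(Nc2cccc3c2CCC3)n1` gives 3900 nM, the highest of the three; its gap to compound 1 lies within the scatter, its gap to compound 2 beyond it. Compound 4 `CCOC(=O)CSc1nc(Cl)cc(Nc2cccc3c2CCC3)n1` differs from compound 3 by ethyl in place of hydrogen on an oxygen next to a carbonyl group. For the measured compounds named here, no measured pair shows this change on its own, so no step size is known. Compound 1 and compound 2 both carry the ethyl ester and sit at or below compound 3, so a small step downward, within the scatter, is expected for compound 4, estimated as a 1.6-fold lower number from compound 3 to compound 4 (0.19 log units; within the scatter). Compound 4 is expected at 2500 nM, with a range of 1000 nM to 6500 nM.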

Compound 4, half-maximal inhibitory concentration: 3200 nM
For compound 4 the middle estimate is 1.3-fold (0.11 log units) below the measured one; the measured number falls inside the stated range.
By their numbers in this assay, from the lowest: compounds 2, 1, 4 and 3 (each within the scatter of the next, the first and the last beyond it).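

In this assay, for the compounds shown here, this is the first pair that isolates the change: ethyl in place of hydrogen on an oxygen next to a carbonyl group gives a 1.2-fold lower number from compound 3 to compound 4 (0.09 log units; within the scatter) and so carboxy to ethoxycarbonyl on this core stays inside the scatter. The acid and its ethyl ester cannot be told apart on this read-out. No measured evidence bears on this result.

Open, from the compounds shown here alone, is whether a longer chain such as butyl on that oxygen, or an amide in place of the ester, would move the number beyond the scatter. Going by these compounds, whether the step holds on other cores also stays open.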